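Benzisoselenazolone-thiadiazoles: moving from compound 2 to compound 3

The source may report more compounds than this note shows. Statements on the series, on what has been measured and on what is new or still open speak of the compounds shown alone.

Measured so far:
- compound 1 `COc1cc(-c2nnc(-n3[se]c4ccccc4c3=O)s2)cc(OC)c1OC`: 7150 nM
- compound 2 `O=c1c2ccccc2[se]n1-c1nnc(-c2ccc(Cl)cc2)s1`: 24400 nM

In a functional assay on SSMC-7721 cells (Homo sapiens) for antiproliferative activity, read by CCK-8 assay, with a stated time of 48 h (a higher number here means a weaker inhibitor, a lower number a stronger inhibitor), compound 1 gives 7150 nM. In this assay compound 2 gives 24400 nM, the higher of the two numbers; the gap between compound 2 and compound 1 lies beyond the usual scatter, so compound 2 is the weaker of the pair. For the measured compounds named here, no pair differing in a single place has been measured, so no step size is known for this series.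

Compound 3 `O=c1c2ccccc2[se]n1-c1nnc(-c2ccccc2Br)s1` has not yet been measured. It differs from compound 2 by 2-bromophenyl in place of 4-chlorophenyl on an aromatic carbon. Going by the values given here, one halogenated phenyl is exchanged for another, and the only reference points are compound 2 and compound 1. The step of a 1.2-fold lower number from compound 2 to compound 3 (0.09 log units; within the scatter) is expected to be small, with no clear direction beyond the scatter. Compound 3 is therefore estimated at 20000 nM, with a range from 7000 nM to 60000 nM.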

Compound 3, half-maximal inhibitory concentration: 27400 nM
For compound 3 the middle estimate is 1.4-fold (0.14 log units) below the measured one, and the stated range covers the measured number.
By their numbers in this assay, from the lowest: compound 1; then compounds 2 and 3 (each within the scatter of the next).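

In this assay the series now has its first single-place step: 2-bromophenyl in place of 4-chlorophenyl on an aromatic carbon of the five-membered aromatic ring gives a 1.1-fold higher number from compound 2 to compound 3 (0.05 log units; within the scatter), so this exchange leaves the number within the scatter. At this position, the halogen and its place on the phenyl ring can therefore change together without a readable shift, although the two changes cannot be separated from this single step. No measurement shown here bears on the reason for this result.

A 2-chlorophenyl or a 4-bromophenyl would separate the identity of the halogen from its place on the ring. As far as these compounds go, whether an unsubstituted phenyl, or a phenyl carrying an amine or a carboxylic acid, would give a step beyond the scatter remains open.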